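The compounds below may be only part of what the source reports. "The series", "measured", "known", "first", "only" and "open" are said of these compounds alone.

Measured so far in an ADME assay on HepG2 2.2.15 cells (Homo sapiens) for cytotoxicity; on this read-out lower numbers stand for higher toxicity in this test and higher numbers for lower toxicity in this test:
- compound 1 `O=CCc1c(-c2ccccc2Cl)c2cc(Cl)ccc2[nH]c1=O`: 120000 nM
- compound 2 `CC(C)C(=O)OCCc1c(-c2ccccc2Cl)c2cc(Cl)ccc2[nH]c1=O`: 62000 nM
- compound 3 `O=C(CCC1CCCCC1)OCCc1c(-c2ccccc2Cl)c2cc(Cl)ccc2[nH]c1=O`: 160000 nM

Compound 3 stands level with compound 1 within the scatter, and only compound 2 sits apart from it. Compound 4 `O=C(OCCc1c(-c2ccccc2Cl)c2cc(Cl)ccc2[nH]c1=O)c1cccnc1` has not yet been measured in this assay. Its difference from compound 3 is pyridin-3-yl in place of 2-cyclohexylethyl on a carbonyl carbon.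

The closest evidence is a 2.6-fold higher number from compound 2 to compound 3 (0.41 log units; beyond the scatter), a change on that same carbonyl carbon, with 2-cyclohexylethyl in place of isopropyl. The other measured step, a 1.9-fold lower number from compound 1 to compound 2 (0.29 log units; within the scatter), is a change of another kind, ((isopropylcarbonyl)oxy)methyl in place of formyl, and it stays within the scatter, so it adds little here. Among the compounds with values here, no measured compound carries pyridin-3-yl, which leaves the direction weakly founded. Removing 2-cyclohexylethyl is expected to give back part of the rise seen from the isopropyl ester, moving toward compound 2 at 62000 nM, without exceeding the measured step in size. The expected change is a 1.7-fold lower number from compound 3 to compound 4 (0.23 log units; within the scatter). Compound 4 is estimated at 95000 nM, with an expected range from 42000 nM to 210000 nM.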

Compound 4, half-maximal cytotoxic concentration: 170000 nM
For compound 4 the middle estimate is 1.8-fold (0.25 log units) below the measured one; the measured number falls inside the stated range.
By their numbers in this assay, from the lowest: compounds 2, 1, 3 and 4 (each within the scatter of the next, the first and the last beyond it).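

In this assay, exchanging the saturated 2-cyclohexylethyl for the aromatic pyridin-3-yl on the same carbonyl carbon leaves the read-out level (a 1.1-fold higher number from compound 3 to compound 4 (0.03 log units; within the scatter)), so at this position the series tolerates a change of ring type and the entry of a ring nitrogen without a readable shift. The step from the isopropyl ester is modest but beyond the scatter (a 2.7-fold higher number from compound 2 to compound 4 (0.44 log units; beyond the scatter)), and with compound 3 also apart from compound 2, two structurally different groups now stand clear of isopropyl in the direction of lower toxicity in this test, while the step from the formyl compound stays within the scatter (a 1.4-fold higher number from compound 1 to compound 4 (0.15 log units; within the scatter)). Nothing available here accounts for these steps or for the isopropyl ester standing apart.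

Plain phenyl on the carbonyl carbon would show whether the ring nitrogen matters at all, and ethyl or tert-butyl would show whether the gap belongs to isopropyl alone or to short alkyl groups generally. As far as these compounds go, how an amine or a carboxylic acid on this ester group would read remains open.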